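This account rests on a few compounds, and the source may have more. Where it says the series, first, only, none or still open, it means among the compounds named here.

Working notes on the series.

Compound 1 `CN(C)Cc1cc(S(N)(=O)=O)ccc1Sc1ccc(C(F)(F)F)cc1` and compound 2 `CSc1ccc(Sc2ccc(S(N)(=O)=O)cc2CN(C)C)cc1` share one core. In an assay on HEK293 cells for inhibition of sodium-dependent dopamine transporter (Homo sapiens) (on this read-out higher numbers stand for weaker inhibition and lower numbers for stronger inhibition), compound 1 gives only a limit of the assay, > 10000 nM. Of the two values shown, one sits at that limit (the limit of > 10000 nM in this assay, at which 1 of the 2 values shown sits). For compound 2 no result is reported in this assay, "not determined" (no result reported), so compound 2 stands on no number at all. Going by the values given here, no step between measured compounds can be read off from these two entries.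

Compound 3 `CSc1ccc(Sc2ccc(N(C)S(C)(=O)=O)cc2CN(C)C)cc1` is the next member. It differs from compound 2 by a single change: methyl(methylsulfonyl)amino in place of sulfamoyl on an aromatic carbon. Among the compounds with values here, there is no measured step to set a size or direction for this change, and with compound 1 resting at a limit, no step beyond the scatter is expected in either direction. The estimate for compound 3 in this assay is 15000 nM, with a range from 3000 nM to 60000 nM, and a result reported only as a limit is expected more often than not.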

Compound 3, half-maximal inhibitory concentration: 3600 nM
The estimate for compound 3 lay 4.2-fold (0.62 log units) above the measured number, within the range that was stated.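

Going by these compounds alone, no new step can be read from compound 1, compound 2 and compound 3: compound 3 gives 3600 nM, but no pair differing in one place links two numbers. Going by these compounds, the size and direction of replacing sulfamoyl with methyl(methylsulfonyl)amino in this assay stay open.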